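The source may report more compounds than this note shows. Statements on the series, on what has been measured and on what is new or still open speak of the compounds shown alone.

Compound 1 `Cc1cc(O)c(C2=NN(c3ccc(S(N)(=O)=O)cc3)C(c3ccccc3O)C2)cc1Cl`: 3020 nM
Compound 2 `Cc1cc(O)c(C2=NN(c3ccc(S(N)(=O)=O)cc3)C(c3ccccc3Cl)C2)cc1Cl`: 3250 nM

In a functional assay on SF-539 cells (Homo sapiens) for antiproliferative activity, with a stated time of 48 h (on this read-out higher numbers stand for weaker inhibition of growth and lower numbers for stronger inhibition of growth), compound 2 gives 3250 nM, the highest of the two numbers, and the nearest value, that of compound 1, is 3020 nM, a gap told by a 1.1-fold higher number from compound 1 to compound 2 (0.03 log units; within the scatter). Compound 3 `Cc1cc(O)c(C2=NN(c3ccc(S(N)(=O)=O)cc3)C(/C=C/c3ccccc3)C2)cc1Cl` differs from compound 2 by 2-phenylethenyl in place of 2-chlorophenyl on a saturated ring carbon. Going by the values given here, the single measured step, a 1.1-fold higher number from compound 1 to compound 2 (0.03 log units; within the scatter), concerns a different exchange and does not bear on this one, so there is no basis for a direction. Compound 3 is therefore expected to show no step beyond the scatter, a 1.1-fold higher number from compound 2 to compound 3 (0.03 log units; within the scatter). Compound 3 is estimated at 3500 nM, within 1200 nM to 10000 nM.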

Compound 3, concentration for total growth inhibition: 14000 nM
Beside the measured number, compound 3's estimate is 4.0-fold (0.60 log units) below it, outside the stated range (above it).
By their numbers in this assay, from the lowest: compounds 1 and 2 (each within the scatter of the next); then compound 3.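

In this assay this saturated ring carbon turns out to respond to its substituent: there is a 4.3-fold higher number from compound 2 to compound 3 (0.63 log units; beyond the scatter) and a 4.6-fold higher number from compound 1 to compound 3 (0.67 log units; beyond the scatter), both toward weaker inhibition of growth. The exchange of 2-hydroxyphenyl for 2-chlorophenyl had shown no change beyond the scatter, so 2-phenylethenyl is the first group here to separate from the others. The compounds shown leave open how a saturated 2-phenylethyl chain, an unsubstituted phenyl or an amine-bearing group would read at this carbon, and whether the double bond itself matters. Nothing available accounts for the loss.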